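A few compounds are considered here, and "the series" means these few. Any claim that something is new, unique, unknown or untested is made for them only; others in the source may bear on it.

Compound 1 `O=c1c2ccccc2c(-c2cccnc2)nn1C1CCCC1` carries a cyclopentyl on an aromatic nitrogen of the shared core. In a functional assay (trachea) with Cavia porcellus as the target (on this read-out lower numbers stand for stronger inhibition and higher numbers for weaker inhibition), compound 1 gives 2750 nM, the lowest of the three numbers in hand. Compound 2 `O=C(c1cccs1)n1nc(-c2cccnc2)c2ccccc2c1=O` gives 12300 nM in this assay. The step is a 4.5-fold higher number from compound 1 to compound 2 (0.65 log units; beyond the scatter). Among the measured compounds shown here, compound 3 `O=c1c2ccccc2c(-c2cccnc2)nn1S(=O)(=O)c1ccccc1` gives 14800 nM in this assay; no single-place step to compound 1 is recorded for it, but its value sits well above that of compound 1.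

Compound 4 `O=C(O)Cn1nc(-c2cccnc2)c2ccccc2c1=O` is not yet measured. The change from compound 1 is carboxymethyl in place of cyclopentyl on an aromatic nitrogen. For the measured compounds named here, the one measured step at this position, a 4.5-fold higher number from compound 1 to compound 2 (0.65 log units; beyond the scatter), went to a higher number, and compound 3 likewise shows a higher number than compound 1; both replacements of the cyclopentyl at this nitrogen point the same way, though neither introduces a carboxymethyl, so the size remains uncertain. A step of a 3.6-fold higher number from compound 1 to compound 4 (0.56 log units; beyond the scatter) is expected in this assay. Compound 4 is estimated at 10000 nM in this assay, with a range from 3000 nM to 35000 nM.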

Compound 4, half-maximal inhibitory concentration: > 100000 nM
Compound 4: a limit, no number (the forecaster's own chance of this, stated with the estimate: 15%); middle value at least 10-fold (1.00 log units) away from the limit.
By their numbers in this assay, from the lowest: compound 1; then compounds 2 and 3 (each within the scatter of the next). At a limit, above all of these: compound 4.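

Compound 4 stands at a limit, not a number, in this assay: the limit of > 100000 nM in this assay, at which 1 of the 4 values shown sits.

Even as a limit it widens the span at this aromatic nitrogen, with an at least 36-fold higher number from compound 1 to compound 4 (1.56 log units; beyond the scatter) and an at least 8.1-fold higher number from compound 2 to compound 4 (0.91 log units; beyond the scatter). The earlier replacements of cyclopentyl still gave measurable numbers, whereas carboxymethyl, which brings a hydrogen-bond donor where cyclopentyl has none, does not, so this position separates substituents far more sharply than compounds 2 and 3 could show.

Going by these compounds, it remains open whether the loss follows the free carboxylic acid itself or any short non-ring chain at this nitrogen; a methyl ester, a primary amide or a longer chain ending in a carboxylic acid would separate these. An amine on the same chain would show whether other groups in this place fare equally badly.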